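The source may hold more compounds than are shown below. What is called first, only, known or untested is meant among the compounds shown, and "the series" means these compounds.

In a physicochemical assay for solubility, read by LC-MS, in phosphate buffer, with a stated time of 24 h, at pH 7.4 (a lower number here means a less soluble compound, a higher number a more soluble compound), compound 1 `Cc1nccn1-c1cnc(NCc2c(F)ccc3c2CCO3)c2cn[nH]c(=O)c12` gives 7000 nM and compound 2 `O=C1c2ccccc2CN1c1cnc(NCc2c(F)ccc3c2CCO3)n2cnnc12` gives 4000 nM, two numbers that lie within the usual scatter of each other. Compound 3 `O=C1CCCN1c1cnc(NCc2c(F)ccc3c2CCO3)c2cn[nH]c(=O)c12` is reported only as a limit, < 2000 nM.

Compound 4 `COCCC(=O)Nc1cnc(NCc2c(F)ccc3c2CCO3)n2cnnc12` has not yet been measured. It departs from compound 2 in one place: a group of 7 heavy atoms (4 carbon, 1 nitrogen, 2 oxygen; no ring) in place of a group of 10 heavy atoms (8 carbon, 1 nitrogen, 1 oxygen; one five-membered non-aromatic ring with 1 hetero atom, one six-membered aromatic ring of carbon only), on an aromatic carbon. The new group, ((2-methoxyethyl)carbonyl)amino, has no ring, whereas the group it replaces has two, and it sits on an aromatic carbon.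

Among the compounds with values here, only one measured step offers a comparison, because it too swaps a group on an aromatic carbon: an at least 3.5-fold lower number from compound 1 to compound 3 (0.54 log units; beyond the scatter). There, 2-oxopyrrolidin-1-yl takes the place of 2-methyl-1H-imidazol-1-yl. Within the data shown here, that step belongs to the core of compound 1, not the core of compound 2, and neither group involved is the one in this change, so it is only a loose guide. It points towards a lower number, but a small shift is the most that seems reasonable to expect. The expected change is a 1.3-fold lower number from compound 2 to compound 4 (0.12 log units; within the scatter), which is not clearly beyond the scatter. The reading could also end at the limit of < 2000 nM in this assay, at which 1 of the 3 values shown sits, leaving only a limit. For compound 4 the estimated value is 3000 nM, with an expected range of 1200 nM to 9000 nM.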

Compound 4, solubility: 980000 nM
Beside the measured number, compound 4's estimate is 330-fold (2.51 log units) below it; the whole stated range lies below it.
By their numbers in this assay, from the lowest: compounds 2 and 1 (each within the scatter of the next); then compound 4. At a limit, below all of these: compound 3.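

In this assay, this position on an aromatic carbon of the shared core proves far from neutral: a 250-fold higher number from compound 2 to compound 4 (2.39 log units; beyond the scatter), a large step well beyond the scatter. Within the data shown here, the only earlier step, an at least 3.5-fold lower number from compound 1 to compound 3 (0.54 log units; beyond the scatter), exchanged one ring-bearing group for another on a different core, whereas here a group with two rings gives way to ((2-methoxyethyl)carbonyl)amino, which has no ring and carries a hydrogen-bond donor that the old group lacks, so this is the first sign of how far the number can move when the rings leave this carbon. Nothing measured here gives a reason for the size of this step.

The single change bundles several differences together, so the loss of the rings, the arrival of the amide hydrogen and the methoxy end cannot be told apart in the compounds shown. Also open, on these data alone, is how a plain acetylamino group, a longer ether chain or a simple amine would read at this carbon, and whether ((2-methoxyethyl)carbonyl)amino would give a similar step on the core of compound 1.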